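The source may report more compounds than this note shows. Statements on the series, on what has been measured and on what is new or still open speak of the compounds shown alone.

Measured so far in an ADME assay on MRC5 cells (Homo sapiens) for inhibition, with a stated time of 72 h; on this read-out lower numbers stand for an effect already at smaller amounts and higher numbers for an effect only at larger amounts of compound:
compound 1 `COc1cccc(OC)c1C(=O)Nc1c[nH]nc1C(=O)N[C@H]1CC[C@H](O)CC1` gives 34000 nM
compound 2 `CO[C@H]1CC[C@H](NC(=O)c2n[nH]cc2NC(=O)c2ccccc2)CC1` gives 800 nM
compound 3 `CO[C@H]1CC[C@H](NC(=O)c2n[nH]cc2NC(=O)c2ccccc2C(F)(F)F)CC1` gives 3300 nM

Compound 1 has the highest number of the three, beyond the scatter from both others. Compound 4 `COc1cccc(OC)c1C(=O)Nc1c[nH]nc1C(=O)NCc1ccccc1` keeps the core of compound 1 but has benzyl in place of 4-hydroxycyclohexyl on an amide-type nitrogen in the structure. Going by the values given here, no measured step covers this change. Among the compounds with values here, the only step is a 4.1-fold higher number from compound 2 to compound 3 (0.62 log units; beyond the scatter) and it lies at another place, so it guides size only. A modest or somewhat larger step toward a lower number in this assay is expected, though the direction is uncertain. The estimated change is a 2.8-fold lower number from compound 1 to compound 4 (0.45 log units; beyond the scatter) in this expectation. For compound 4 the expected value is 12000 nM with an estimated range of 3000 nM to 40000 nM as its bounds.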

Compound 4, half-maximal effective concentration: 50000 nM
Estimate against measurement, compound 4: 4.2-fold (0.62 log units) below; the measured number lies above the stated range.
By their numbers in this assay, from the lowest: compound 2; then compound 3; then compounds 1 and 4 (each within the scatter of the next).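

On the amide-type nitrogen of the core of compound 1, this assay gives a 1.5-fold higher number from compound 1 to compound 4 (0.17 log units; within the scatter) for benzyl in place of 4-hydroxycyclohexyl. The read-out therefore does not separate these two groups at this place, even though the aromatic ring carries no hydrogen-bond donor or acceptor and the non-aromatic ring carries both. No available evidence bears on this result.

From the compounds shown here alone, whether an amine, a carboxylic acid or a longer chain on this nitrogen would separate from these two groups remains open. Also open, going by these compounds, is whether benzyl reads the same on the core of compound 2.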